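Swapping a Dimethoxyphenyl for a Chlorophenyl: What to Expect

This account rests on a few compounds, and the source may have more. Where it says the series, first, only, none or still open, it means among the compounds named here.

Of the compounds shown here, three that share a common core have been measured in a functional assay on U-87MG ATCC cells for antiproliferative activity against U-87 MG (Homo sapiens), read by MTT assay, with a stated time of 48 h, tested at 10 uM; on this read-out lower numbers stand for a stronger effect and higher numbers for a weaker effect at the one concentration tested. Compound 2 `COc1ccc(-c2nc(C)c(C(=O)CSc3nc(-c4ccc(OC)c(OC)c4)c(C#N)c(=O)[nH]3)s2)cc1` gives 57.6%, the lowest number of the three. Compound 1 `COc1ccc(-c2nc(C)c(C(=O)CSc3nc(-c4ccc(Cl)cc4)c(C#N)c(=O)[nH]3)s2)cc1` gives 92.7%, and compound 3 `COc1ccc(-c2nc(SCC(=O)c3sc(-c4ccccc4)nc3C)[nH]c(=O)c2C#N)cc1OC` gives 69.8%.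

Two single changes connect these measurements. From compound 2 to compound 1 the change is 4-chlorophenyl in place of 3,4-dimethoxyphenyl on an aromatic carbon, and it brought a number 35.1 percentage points higher from compound 2 to compound 1 (beyond the scatter). From compound 2 to compound 3 the change is hydrogen in place of methoxy on an aromatic carbon, and it brought a number 12.2 percentage points higher from compound 2 to compound 3 (beyond the scatter).

Compound 4 `Cc1nc(-c2ccccc2)sc1C(=O)CSc1nc(-c2ccc(Cl)cc2)c(C#N)c(=O)[nH]1` has not yet been measured. It differs from compound 3 by 4-chlorophenyl in place of 3,4-dimethoxyphenyl on an aromatic carbon, which is the same change that separates compound 2 from compound 1, and the surroundings of the altered position are described in identical words in both pairs. The two starting points, compound 2 and compound 3, differ from each other only in the way already described for that pair, so the new step is made on a slightly different core.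

Because the earlier example of this change gave a number 35.1 percentage points higher from compound 2 to compound 1 (beyond the scatter), a step in the same direction is expected from compound 3 to compound 4, estimated at a number 26.2 percentage points higher from compound 3 to compound 4 (beyond the scatter); it is expected to be somewhat smaller only since compound 3 starts closer to the point where the cells grow as untreated ones do. Compound 4 is therefore expected to give about 96%, with a plausible range from 84% to 106%.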

Compound 4, a percentage reported as activity, at one concentration (the size of the read-out at that concentration, not a potency): 85.2%
The estimate for compound 4 lay 10.8 percentage points above the measured number, within the range that was stated.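

On the second core the change again went the same way, with a number 15.4 percentage points higher from compound 3 to compound 4 (beyond the scatter) in this assay, so the direction carried over from one core to the other, but the size did not: the same change on two cores in this assay, a number 35.1 percentage points higher (beyond the scatter) from compound 2 to compound 1 and a number 15.4 percentage points higher (beyond the scatter) from compound 3 to compound 4, 19.7 percentage points apart, beyond the scatter of two such steps

The same dependence on the surroundings appears when the pairs are read the other way, through hydrogen in place of methoxy, where the core bearing the 4-chlorophenyl group gives a number 7.5 percentage points lower from compound 1 to compound 4 (within the scatter), and this step does not match its counterpart on the core bearing the 3,4-dimethoxyphenyl group: the same change on two cores in this assay, a number 12.2 percentage points higher (beyond the scatter) from compound 2 to compound 3 and a number 7.5 percentage points lower (within the scatter) from compound 1 to compound 4, 19.7 percentage points apart, beyond the scatter of two such steps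

These two pairs show that, within this small set, the size of a step cannot simply be copied from one core to another, but they do not show why the steps differ or how the change would behave on any further core.

The compounds shown carry only a 3,4-dimethoxyphenyl or a 4-chlorophenyl group on this aromatic carbon, so it remains open how an amine, a carboxylic acid or a longer chain would fare there. As far as these compounds go, it also remains open whether these steps would look the same at other concentrations or in other cell lines, as a reading at a single concentration is not a potency.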